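This account rests on a few compounds, and the source may have more. Where it says the series, first, only, none or still open, it means among the compounds named here.

Measured so far in a functional assay on B16-F10 cells (Mus musculus) for antiproliferative activity, read by MTT assay, with a stated time of 48 h; on this read-out higher numbers stand for weaker inhibition and lower numbers for stronger inhibition:
- compound 1 `CCCCOc1ccc(C(=O)/C=C/c2c(/C=C/c3ccc(OC)cc3)cc(OC)cc2OC)cc1`: 5.3 ug/mL
- compound 2 `COc1ccc(/C=C/c2cc(OC)cc(OC)c2/C=C/C(=O)c2ccc(C)cc2C)cc1`: 4 ug/mL

Among the compounds with values here, compound 1 holds the highest of the two numbers; its only neighbour is compound 2, and the step of a 1.3-fold lower number from compound 1 to compound 2 (0.12 log units; within the scatter) lies within the scatter, so no order between them can be claimed.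

Compound 3 `COc1ccc(/C=C/c2cc(OC)cc(OC)c2/C=C/C(=O)c2ccc(OC)cc2)cc1` is not yet measured. Relative to compound 1 the change is hydrogen in place of propyl on a saturated chain carbon bound to an oxygen on an aromatic ring. Within the data shown here, the single measured step touching the 4-butoxyphenyl on the carbonyl carbon is a 1.3-fold lower number from compound 1 to compound 2 (0.12 log units; within the scatter), a replacement of the whole ring that moved nothing beyond the scatter. A smaller trim of the same butoxy group is therefore expected to give a step of a 1.1-fold lower number from compound 1 to compound 3 (0.03 log units; within the scatter), with no direction beyond the scatter. Compound 3 is estimated at 5 ug/mL, ranging from 2.5 ug/mL to 10 ug/mL.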

Compound 3, half-maximal inhibitory concentration: 5.8 ug/mL
For compound 3 the middle estimate is 1.2-fold (0.06 log units) below the measured one, within the range that was stated.
By their numbers in this assay, from the lowest: compounds 2, 1 and 3 (each within the scatter of the next).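

Going from 4-butoxyphenyl to 4-methoxyphenyl on the carbonyl carbon gives a 1.1-fold higher number from compound 1 to compound 3 (0.04 log units; within the scatter) in this assay, so trimming the chain from butyl to methyl leaves the number as unresolved as replacing the whole ring did. Exchanging 2,4-dimethylphenyl for 4-methoxyphenyl gives a 1.5-fold higher number from compound 2 to compound 3 (0.16 log units; within the scatter), and thus all three aryl ketones remain unordered. No evidence on the cause of this flat result is available.

From the compounds shown here alone, it remains open whether any change at this ring can move the number beyond the scatter. An amine, a carboxylic acid or a chain longer than butyl at this place remains untested among the compounds shown.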